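The source may report more compounds than this note shows. Statements on the series, on what has been measured and on what is new or still open speak of the compounds shown alone.

Measured so far:
compound 1 `COCC1=C(C(=O)OC)C(c2cc(F)c(F)cc2F)N(C(=O)NCCCN2CCN(c3ccccc3C(N)=O)CC2)C(=O)N1` — 0.1 nM
compound 2 `CCOc1ccccc1N1CCN(CCCNC(=O)N2C(=O)NC(C)=C(C(=O)OC)C2c2ccc(F)c(F)c2)CC1` — 0.1 nM
compound 3 `CC(=O)C1=C(C)NC(=O)N(C(=O)NCCCN2CCN(c3ccccc3C(N)=O)CC2)C1c1ccc(F)c(F)c1` — 0.7 nM

In an assay on liver for binding affinity to Alpha-1A adrenergic receptor (Homo sapiens), using microsomes (on this read-out higher numbers stand for weaker inhibition and lower numbers for stronger inhibition), compound 2 gives 0.1 nM. Compound 1 gives 0.1 nM in this assay, the same number at the digits shown, so the two are within the scatter of each other and together hold the lowest numbers of the three. Compound 3 gives 0.7 nM, a higher number than compound 2 that lies beyond the scatter.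

The next compound in the series is compound 4 `COC(=O)C1=C(C)NC(=O)N(C(=O)NCCCN2CCN(c3cccc(Cl)c3)CC2)C1c1ccc(F)c(F)c1`. It is compound 2 with one change: 3-chlorophenyl in place of 2-ethoxyphenyl on an amine nitrogen in a ring. Among the compounds with values here, no measured pair in the set shows this particular exchange, so its effect is not known from the data here.

Because compound 2 sits at 0.1 nM, very low already, an exchange on the amine nitrogen in the ring is expected to move the number upward rather than downward; the step from compound 2 to compound 4 is estimated as a modest rise, a 3.0-fold higher number from compound 2 to compound 4 (0.48 log units; beyond the scatter), possibly within the scatter. For compound 4 the value in this assay is expected near 0.3 nM, with a plausible range from 0.08 nM to 1.5 nM.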

Compound 4, inhibition constant: 0.7 nM
Estimate against measurement, compound 4: 2.3-fold (0.37 log units) below, and the stated range covers the measured number.
By their numbers in this assay, from the lowest: compounds 1 and 2 (each within the scatter of the next); then compounds 3 and 4 (each within the scatter of the next).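

In this assay, the exchange of 2-ethoxyphenyl for 3-chlorophenyl on an amine nitrogen in a ring gives a 7.0-fold higher number from compound 2 to compound 4 (0.85 log units; beyond the scatter), the first step read at this position in the series. The group on this nitrogen therefore affects the number, although compound 4 at 0.7 nM still binds at a low value in this read-out; the exchange also replaces a group holding a hydrogen-bond acceptor with one holding none, and it changes both the substituent and its place on the phenyl ring. Nothing among the available data accounts for the rise.

With both features changed in a single step, the contribution of each stays unresolved, and pairs carrying 2-chlorophenyl, 3-ethoxyphenyl or unsubstituted phenyl on the same nitrogen would be needed to separate them. Within the data shown here, also open is whether a step of this size carries over to the other cores in the set, such as the one bearing an acetyl group or a methoxymethyl group, and how a pyridine ring would behave at this position.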